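From fluoro to methoxy: compound 3 to compound 4

A few compounds are considered here, and "the series" means these few. Any claim that something is new, unique, unknown or untested is made for them only; others in the source may bear on it.

Of the compounds shown here, three on the shared core have been measured in an ADME assay on MDCK cells (Canis lupus familiaris) for cytotoxicity, read by MTT assay, with a stated time of 72 h; on this read-out higher numbers stand for lower toxicity in this test and lower numbers for higher toxicity in this test. Compound 1 `Cc1nc([N+](=O)[O-])cn1S(=O)(=O)c1ccc([N+](=O)[O-])cc1` gives 611000 nM, compound 2 `Cc1nc([N+](=O)[O-])cn1S(=O)(=O)c1ccccc1` gives 1270000 nM and compound 3 `Cc1nc([N+](=O)[O-])cn1S(=O)(=O)c1ccc(F)cc1` gives 813000 nM. Compound 3 cannot be separated from either of the others: a 1.3-fold higher number from compound 1 to compound 3 (0.12 log units; within the scatter), and a 1.6-fold lower number from compound 2 to compound 3 (0.19 log units; within the scatter). Among the compounds with values here, only one pair stands apart, and modestly: a 2.1-fold higher number from compound 1 to compound 2 (0.32 log units; beyond the scatter).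

The next compound is compound 4 `COc1ccc(S(=O)(=O)n2cc([N+](=O)[O-])nc2C)cc1`, with methoxy in place of fluoro on an aromatic carbon. Within the data shown here, no measured step makes this exchange, so the evidence is indirect. The three measured steps all change the group at this same place, and the largest of them is the modest step between compound 1 and compound 2 given above. The two steps that bring in fluoro stay within the scatter. On that basis, no step beyond the scatter is expected in this assay, and no firm direction can be drawn. The expected step is a 1.2-fold higher number from compound 3 to compound 4 (0.09 log units; within the scatter). For compound 4 the estimated value is 1000000 nM, with an expected range from 550000 nM to 1800000 nM.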

Compound 4, half-maximal cytotoxic concentration: 321000 nM
Compound 4: middle estimate off by 3.1-fold (0.49 log units), on the high side, and the stated range ends above it.
By their numbers in this assay, from the lowest: compounds 4, 1, 3 and 2 (each within the scatter of the next, the first and the last beyond it).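

Working notes: in this assay, the place para to a large group responds more strongly than the earlier compounds showed, with a 4.0-fold lower number from compound 2 to compound 4 (0.60 log units; beyond the scatter) now the largest step there and methoxy also separating from fluoro in a 2.5-fold lower number from compound 3 to compound 4 (0.40 log units; beyond the scatter). Methoxy cannot be told apart from nitro, as a 1.9-fold lower number from compound 1 to compound 4 (0.28 log units; within the scatter) shows, yet compound 1 and compound 4 both stand apart from compound 2 beyond the scatter, while compound 3 does not, so a substituent at this place does not by itself separate a compound from compound 2. Nothing available explains why methoxy departs from fluoro and hydrogen here.

The compounds shown leave open whether the oxygen of methoxy or its added carbon goes with the lower number, a question that hydroxy, ethoxy or a plain methyl group at the same place could address. On these data alone, an amine or a carboxylic acid at this place would also show whether the span of this series extends further, and whether the separation seen here holds in any test other than this assay remains unknown.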